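This account rests on a few compounds, and the source may have more. Where it says the series, first, only, none or still open, it means among the compounds named here.

In an ADME assay on HepG2 2.2.15 cells (Homo sapiens) for cytotoxicity (a higher number here means that more compound is tolerated, a lower number that less compound is tolerated), compound 1 `O=c1[nH]c2ccc(Cl)cc2c(-c2ccccc2Cl)c1CCO` gives 380000 nM. Compound 2 `CCC(=O)OCCc1c(-c2ccccc2Cl)c2cc(Cl)ccc2[nH]c1=O` gives 95000 nM, and compound 3 `CC(=O)OCC(=O)OCCc1c(-c2ccccc2Cl)c2cc(Cl)ccc2[nH]c1=O` gives 100000 nM. Compound 3 therefore sits under compound 1 and cannot be told apart from compound 2. Compound 4 `O=C(OCCc1c(-c2ccccc2Cl)c2cc(Cl)ccc2[nH]c1=O)C1CCCC1` puts cyclopentyl in place of acetoxymethyl on a carbonyl carbon. Replacing the hydrogen on the oxygen gave a 4.0-fold lower number from compound 1 to compound 2 (0.60 log units; beyond the scatter) and a 3.8-fold lower number from compound 1 to compound 3 (0.58 log units; beyond the scatter), both modest. Among the measured compounds shown here, exchanging one ester group for the other gave a 1.1-fold higher number from compound 2 to compound 3 (0.02 log units; within the scatter), and that is the closest precedent. For the measured compounds named here, no change beyond the scatter is thus expected in this assay, although no measured compound carries a ring in this group. The expected step is a 1.3-fold lower number from compound 3 to compound 4 (0.10 log units; within the scatter). Compound 4 is estimated at 80000 nM, with an expected range of 35000 nM to 180000 nM.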

Compound 4, half-maximal cytotoxic concentration: 46000 nM
For compound 4 the middle estimate is 1.7-fold (0.24 log units) above the measured one; low and high end bracket the measured number.
By their numbers in this assay, from the lowest: compound 4; then compounds 2 and 3 (each within the scatter of the next); then compound 1.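

In this assay the group on the carbonyl carbon does count: ethyl and acetoxymethyl could not be told apart, yet cyclopentyl gives a 2.2-fold lower number from compound 3 to compound 4 (0.34 log units; beyond the scatter) and a 2.1-fold lower number from compound 2 to compound 4 (0.31 log units; beyond the scatter). Compound 4 thus has the lowest number of the series, with an 8.3-fold lower number from compound 1 to compound 4 (0.92 log units; beyond the scatter). Nothing at hand explains this shift.

Because cyclopentyl brings a ring and also removes the oxygens of acetoxymethyl, the compounds shown do not separate these two differences. An open pentyl chain, a tetrahydrofuranyl ring or an amine on this carbonyl carbon would remain to be compared.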